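The source may report more compounds than this note shows. Statements on the series, on what has been measured and on what is new or still open speak of the compounds shown alone.

In an assay on CHO cells for displacement of a labelled ligand from melanin-concentrating hormone receptor 1 (Homo sapiens), read by scintillation counting, with a stated time of 1 h (a higher number here means a weaker inhibitor, a lower number a stronger inhibitor), the two measured compounds gave:

Compound 1, `Cc1c(C2CC2)nc2ccc(-n3ccc(OCc4ccccc4)cc3=O)cn12`: 42 nM
Compound 2, `Cc1c(C2CC2)nc2ccc(-n3ccc(OCc4ccc(C(F)(F)F)cc4)cc3=O)cn12`: 72 nM

Within the data shown here, compound 2 holds the higher of the two numbers, its nearest neighbour being compound 1, and the single measured step, a 1.7-fold higher number from compound 1 to compound 2 (0.23 log units; within the scatter), is within the scatter, so the two compounds cannot be set apart on these numbers. Compound 3, `Cc1c(C2CC2)nc2ccc(-n3ccc(OCc4csc(C(F)(F)F)c4)cc3=O)cn12`, is still to be measured; it differs from compound 2 by 5-(trifluoromethyl)thiophen-3-yl in place of 4-(trifluoromethyl)phenyl on a saturated chain carbon bound to an oxygen on an aromatic ring. Among the measured compounds shown here, only the step from compound 1 to compound 2 touches the same part of the molecule, the group carried on the chain carbon bound to the ring oxygen, and that step stayed within the scatter. For the measured compounds named here, there is no measured example of the ring itself being exchanged, so the available comparison is thin. On this basis no step beyond the scatter is expected from compound 2 to compound 3 in this assay, the expected step being a 1.1-fold higher number from compound 2 to compound 3 (0.05 log units; within the scatter). Compound 3 is therefore estimated at 80 nM, with a range from 30 nM to 220 nM.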

Compound 3, half-maximal inhibitory concentration: 17 nM
Beside the measured number, compound 3's estimate is 4.7-fold (0.67 log units) above it, outside the stated range (below it).
By their numbers in this assay, from the lowest: compound 3; then compounds 1 and 2 (each within the scatter of the next).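

Among these compounds, exchanging the ring on the saturated chain carbon bound to an oxygen on an aromatic ring is the first change at this position to move the number beyond the scatter in this assay, with a 4.2-fold lower number from compound 2 to compound 3 (0.63 log units; beyond the scatter), whereas adding trifluoromethyl to the phenyl ring gave a 1.7-fold higher number from compound 1 to compound 2 (0.23 log units; within the scatter). The new group also separates from the plain phenyl group, with a 2.5-fold lower number from compound 1 to compound 3 (0.39 log units; beyond the scatter), so 5-(trifluoromethyl)thiophen-3-yl gives the lowest number of the three compounds, and its steps to both others are printed as beyond the scatter. No measurement shown here bears on why the thiophene ring gives a lower number than the benzene ring.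

The compounds shown do not separate the contribution of the thiophene ring from that of its trifluoromethyl group, since the only comparison without trifluoromethyl is with the plain phenyl group and a thiophen-3-yl group carrying hydrogen in its place is not among them. From the compounds shown here alone, it also remains open whether the lower number would persist with chlorine or a methyl group in place of trifluoromethyl, or with a pyridine or thiazole ring in place of the thiophene ring.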